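The source may report more compounds than this note shows. Statements on the series, on what has been measured and on what is new or still open speak of the compounds shown alone.

The series shares one framework and varies two outer groups. Compound 1 `CC(C)NCc1ccc(-c2c3ncn(CC4(O)CCN(Cc5ccc(-c6ccco6)cc5Cl)CC4)c(=O)c3nn2C)cc1` gives, in an assay on isolated protein for inhibition of ubiquitin carboxyl-terminal hydrolase 7 (Homo sapiens), with stated times of 30 min and 2 h (on this read-out higher numbers stand for weaker inhibition and lower numbers for stronger inhibition), a value of 29.1 nM. Among the measured compounds shown here, compound 2 `Cn1nc2c(=O)n(CC3(O)CCN(Cc4ccc(-c5ccco5)cc4Cl)CC3)cnc2c1-c1ccc(C2(N)CC2)cc1` gives in this assay a value of 66.1 nM, and the only single-point step measured so far, a 2.3-fold higher number from compound 1 to compound 2 (0.36 log units; beyond the scatter), concerns the group on the aryl ring that is remote from the chloro-bearing ring. Compound 3 `Cn1nc2c(=O)n(CC3(O)CCN(Cc4ccc(-n5ccnc5)cc4Cl)CC3)cnc2c1-c1ccc(CN)cc1` gives in this assay a value of 228 nM, the highest number of the three, standing beyond the scatter from both compound 2 and compound 1.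

Compound 4 `Cn1nc2c(=O)n(CC3(O)CCN(Cc4ccc(-c5ncco5)cc4Cl)CC3)cnc2c1-c1ccc(CN)cc1` has not yet been measured. It differs from compound 3 in one place: 1,3-oxazol-2-yl in place of 1H-imidazol-1-yl on an aromatic carbon. For the measured compounds named here, no measured step bears on this exchange; the step from compound 1 to compound 2 changes a different ring, and compounds 1 and 2 differ from compound 3 in both positions at once, so their lower numbers cannot be assigned to the five-membered ring alone. An expectation for compound 4 in this assay therefore rests on little, and the step of a 1.9-fold lower number from compound 3 to compound 4 (0.28 log units; within the scatter) is estimated to be small and uncertain in direction. Compound 4 is expected to give about 120 nM, in a range from 40 nM to 400 nM.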

Compound 4, half-maximal inhibitory concentration: 1120 nM
Compound 4: the middle estimate sits 9.3-fold (0.97 log units) below what was measured, outside the stated range (above it).
By their numbers in this assay, from the lowest: compound 1; then compound 2; then compound 3; then compound 4.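

In this assay, the exchange gives a 4.9-fold higher number from compound 3 to compound 4 (0.69 log units; beyond the scatter), which is beyond the scatter and means weaker inhibition, so this position, para to a large group and meta to a chloro group, does not treat these two five-membered rings alike. The counted features do not separate them: each group has 5 heavy atoms, one five-membered aromatic ring with 2 hetero atoms, 0 hydrogen-bond donors, 2 hydrogen-bond acceptors and no net charge, and the printed difference in composition is that one nitrogen is replaced by oxygen, while the two rings are also joined through different ring atoms, a nitrogen in 1H-imidazol-1-yl and a carbon in 1,3-oxazol-2-yl. Nothing available here accounts for the difference between these two rings.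

The compounds shown leave open whether this step keeps its size and direction when the aminomethyl group is replaced by (isopropylamino)methyl or 1-aminocyclopropyl. They also leave open where a 1,3-thiazol-2-yl ring, with sulfur in place of the oxygen, or a 1H-pyrazol-1-yl ring, with its two nitrogens side by side, would fall relative to compound 3 and compound 4.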